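Working notes: heteroaryl sulfanyl esters, compound 4

A few compounds are considered here, and "the series" means these few. Any claim that something is new, unique, unknown or untested is made for them only; others in the source may bear on it.

Measured so far:
compound 1 `C=CC(=O)Oc1cc2c(Nc3ccc(F)c(Cl)c3)ncnc2cc1OCC` — 700 nM
compound 2 `CCOc1cc2ncnc(Nc3ccc(F)c(Cl)c3)c2cc1OC(=O)CSc1ccccn1` — 3700 nM
compound 3 `CCOc1cc2ncnc(Nc3ccc(F)c(Cl)c3)c2cc1OC(=O)CSc1ncccn1` — 3600 nM

In a functional assay on NCI-H1975 cells (Homo sapiens) for inhibition, read by MTT assay, with a stated time of 72 h (a higher number here means a weaker inhibitor, a lower number a stronger inhibitor), compound 3 sits second highest of the three numbers; it and compound 2 lie within the scatter of each other, while compound 1 stands apart, as the step of a 5.1-fold higher number from compound 1 to compound 3 (0.71 log units; beyond the scatter) shows. The unmeasured compound 4 `CCOc1cc2ncnc(Nc3ccc(F)c(Cl)c3)c2cc1OC(=O)CSc1nnnn1C` differs from compound 3 by 1-methyl-1H-tetrazol-5-yl in place of pyrimidin-2-yl on a sulfur. Going by the values given here, the one measured step at this position, a 1.0-fold lower number from compound 2 to compound 3 (0.01 log units; within the scatter), exchanged one heteroaryl on the sulfur for another without leaving the scatter. The step from compound 3 to compound 4 is of the same kind, so no change beyond the scatter is expected in this assay: the estimated step is no change at the digits printed from compound 3 to compound 4 (within the scatter). For compound 4 the expected value is 3600 nM, with a range of 1500 nM to 8500 nM.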

Compound 4, half-maximal inhibitory concentration: 2100 nM
For compound 4 the middle estimate is 1.7-fold (0.23 log units) above the measured one; measured number inside the range.
By their numbers in this assay, from the lowest: compound 1; then compounds 4, 3 and 2 (each within the scatter of the next).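

In this assay, a five-membered aromatic ring with four hetero atoms on the sulfur reads the same as the six-membered rings, a 1.7-fold lower number from compound 3 to compound 4 (0.23 log units; within the scatter) and a 1.8-fold lower number from compound 2 to compound 4 (0.25 log units; within the scatter), so the scatter now holds across a change of ring size as well as of hetero atoms. The vinyl ester stays apart from this tetrazole too, a 3.0-fold higher number from compound 1 to compound 4 (0.48 log units; beyond the scatter). Nothing available explains either result.

Open, from the compounds shown here alone, is whether a phenyl or a piperidine ring on the sulfur would give a number beyond the scatter of compound 3.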